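The source may report more compounds than this note shows. Statements on the series, on what has been measured and on what is new or still open speak of the compounds shown alone.

Working notes on the aryl series sharing the core of compound 1 `CC(C)(C)Cc1c(-c2ccc(F)cc2F)sc(N)c1C(=O)c1ccc(Cl)cc1`. In an assay on CHO cells for displacement of a labelled ligand from adenosine receptor A3 (Homo sapiens), read by scintillation counting, tested at 10 uM (a higher number here means more inhibition at the concentration tested (going by the name of the read-out), a lower number less inhibition), compound 1 gives 1%. Compound 2 `CC(C)(C)Cc1c(-c2cc(F)ccc2F)sc(N)c1C(=O)c1ccc(Cl)cc1` gives 1% in this assay, and compound 3 `CC(C)(C)Cc1c(-c2ccc(Cl)cc2)sc(N)c1C(=O)c1ccc(Cl)cc1` gives 1%. Compound 3 stands level with compounds 1 and 2 at the digits shown: the step of no change at the digits printed from compound 1 to compound 3 (within the scatter) and the step of no change at the digits printed from compound 2 to compound 3 (within the scatter) are both flat, as is the step of no change at the digits printed from compound 1 to compound 2 (within the scatter), so none of the aryl groups tried so far separates from the others in this assay.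

Compound 4 `COc1cccc(-c2sc(N)c(C(=O)c3ccc(Cl)cc3)c2CC(C)(C)C)c1` is the next member and is still to be measured in this assay. It differs from compound 3 by 3-methoxyphenyl in place of 4-chlorophenyl on an aromatic carbon. The three measured steps all bear on this, since each exchanges one aryl group for another on the same aromatic carbon, and each was within the scatter. On that basis the step of a number 1 percentage points higher from compound 3 to compound 4 (within the scatter) is expected to stay within the scatter, with no direction beyond it. Compound 4 is therefore estimated at 2% in this assay, in the range -8% to 14%.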

Compound 4, a percentage reported as inhibition, at one concentration (the size of the read-out at that concentration, not a potency): 1%
The estimate for compound 4 lay 1 percentage points above the measured number; the range from low to high includes it.
By their numbers in this assay, from the lowest: compounds 1, 2, 3 and 4 (each within the scatter of the next).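

In this assay, the aromatic carbon next to the ring sulfur also accepts 3-methoxyphenyl, which carries a hydrogen-bond acceptor where 4-chlorophenyl carries none, and the read-out does not separate: the series shows no change at the digits printed from compound 3 to compound 4 (within the scatter), no change at the digits printed from compound 2 to compound 4 (within the scatter) and no change at the digits printed from compound 1 to compound 4 (within the scatter). The flat result now extends beyond halogen-substituted phenyl groups to an oxygen-bearing one, so compound 4 at 1% adds a different kind of substituent without separating from the other three members. No supporting data account for this lack of separation.

Still open, going by these compounds, is whether any group at this position can lift the read-out clear of the scatter, for example a phenyl ring carrying a carboxylic acid or an aminomethyl group, or a non-phenyl ring such as pyridine. Also open, on these data alone, is whether the neopentyl group, the amino group or the (4-chlorophenyl)carbonyl group matters more than the aryl group here, as a shorter chain in place of neopentyl or an acetamide in place of the amino group would test.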